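An ethyl group added to the core of compound 1

This account rests on a few compounds, and the source may have more. Where it says the series, first, only, none or still open, it means among the compounds named here.

Compound 1 `O=C1CS/C(=N\N=C/c2cccnc2)N1Cc1ccco1` gives 500 nM 
Compound 2 `COc1ccc(-c2nnc(NC3=NC(=O)/C(=C/c4ccc(N(C)C)cc4)S3)o2)cc1` gives 150 nM 

Both numbers come from a functional assay on HFL1 cells (Homo sapiens) for inhibition, read by sulforhodamine B assay, with a stated time of 48 h (on this read-out higher numbers stand for weaker inhibition and lower numbers for stronger inhibition), and are the only ones at hand. Compound 1 holds the higher of the two, which makes it the weaker inhibitor of the pair, and the gap to compound 2 lies beyond the scatter. Compound 3 `CCC1S/C(=N\N=C/c2cccnc2)N(Cc2ccco2)C1=O` differs from compound 1 in one place: ethyl in place of hydrogen on a saturated ring carbon with ethyl in place of hydrogen on a saturated ring carbon, next to the ring sulfur. For the measured compounds named here, no measured pair shows what such a change does in this assay so the data give little guidance. No step beyond the scatter is expected, and the estimated move is a 1.3-fold lower number from compound 1 to compound 3 (0.10 log units; within the scatter) in this read-out. Compound 3 is estimated at 400 nM with an expected range from 130 nM to 1200 nM when it is measured.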

Compound 3, half-maximal inhibitory concentration: 210 nM
Compound 3: middle estimate off by 1.9-fold (0.28 log units), on the high side, and the stated range covers the measured number.
By their numbers in this assay, from the lowest: compounds 2 and 3 (each within the scatter of the next); then compound 1.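

In this assay, for the compounds shown here, the saturated ring carbon next to the ring sulfur accepts a substituent without loss of inhibition: ethyl in place of hydrogen brings a 2.4-fold lower number from compound 1 to compound 3 (0.38 log units; beyond the scatter), a modest step and the only measured change at this position. The (furan-2-yl)methyl group and the rest of the core of compound 1 stay the same across this step, so the gain belongs to this single change. Nothing at hand accounts for the gain, and its cause remains unknown.

With only one substituent shown here, the compounds do not tell whether a methyl group or a longer chain such as propyl would give a smaller or a larger step. They also leave open how an amine or a carboxylic acid on the same carbon would behave.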